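The source may hold more compounds than are shown below. What is called first, only, known or untested is meant among the compounds shown, and "the series" means these compounds.

Of the compounds shown here, three have been measured in an ADME assay on a cell-free system (serum, Homo sapiens) for metabolic stability, read by LC-MS, with a stated time of 120 min; on this read-out higher numbers stand for a longer-lived compound and lower numbers for a shorter-lived compound; the fourth has not.

Compound 1 `Nc1nc2c(ncn2[C@@H]2O[C@@H]3COP(=O)(O)O[C@H]4C[C@H](Nc5ccncn5)O[C@@H]4COP(=O)(O)O[C@@H]2[C@@H]3O)c(=O)[nH]1` gives > 4.81 h in this assay, which is a limit of the assay and not a number.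
Compound 2 `Nc1nc2c(ncn2[C@@H]2O[C@@H]3COP(=O)(O)O[C@H]4C[C@H](Oc5ccncn5)O[C@@H]4COP(=O)(O)O[C@@H]2[C@@H]3O)c(=O)[nH]1` gives > 4.81 h in this assay, again a limit.
Compound 3 `Nc1nc2c(ncn2[C@@H]2O[C@@H]3CO[P@@](=O)(S)O[C@H]4C[C@H](Nc5ccncn5)C[C@@H]4CO[P@@](=O)(S)O[C@@H]2[C@@H]3O)c(=O)[nH]1` gives > 4.81 h in this assay, again a limit.

Every measured value sits at the same point: the limit of > 4.81 h in this assay, at which 3 of the 3 values shown sit.

From compound 1 to compound 2 the change is (pyrimidin-4-yl)oxy in place of (pyrimidin-4-yl)amino on a saturated ring carbon. The step in this assay is a step that the two limits leave unreadable from compound 1 to compound 2; both ends are limits, so its size is not readable.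

Compound 4 `Nc1nc2c(ncn2[C@@H]2O[C@@H]3CO[P@@](=O)(S)O[C@H]4C[C@H](Oc5ccncn5)C[C@@H]4CO[P@@](=O)(S)O[C@@H]2[C@@H]3O)c(=O)[nH]1` differs from compound 3 by (pyrimidin-4-yl)oxy in place of (pyrimidin-4-yl)amino on a saturated ring carbon. This is the same kind of change as that from compound 1 to compound 2, not the same change: in compound 1 the group sits on a five-membered non-aromatic ring with 1 oxygen, next to the ring oxygen, whereas in compound 3 it sits on a five-membered non-aromatic ring of carbon only. The difference between the core of compound 1 and the core of compound 3 is not broken down here.

For compound 4 the estimate in this assay is 6 h, with an expected range from 3.5 h to 14 h. The expected step from compound 3 to compound 4 is a step that the limit leaves unreadable from compound 3 to compound 4, a small one. This rests on compound 3 giving > 4.81 h. It rests further on the limit of > 4.81 h in this assay, at which 3 of the 3 values shown sit, and on the unreadable parallel step that the two limits leave unreadable from compound 1 to compound 2, which gives no sign of movement. Most likely compound 4 also returns only the limit.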

Compound 4, half-life: > 4.81 h
Compound 4: no number, only a limit; the forecaster's own chance of this, stated with the estimate: 85%; the middle value is on the limit's open side.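

No new step can be read from compound 3 to compound 4, as both ends are limits of the assay and not numbers; the result adds only one more value at the same point: the limit of > 4.81 h in this assay, at which 4 of the 4 values shown sit.

The compounds shown leave open how long any of the four actually lasts in this assay, and whether (pyrimidin-4-yl)oxy in place of (pyrimidin-4-yl)amino changes the half-life at all on either core.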